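The source may report more compounds than this note shows. Statements on the series, on what has been measured and on what is new or still open speak of the compounds shown alone.

Two compounds share one core and differ only in the group carried on an amine nitrogen in a ring. Compound 1 `O=c1oc(-c2ccccc2)nn1CCCCN1CCN(C2CCCCC2)CC1` bears a cyclohexyl there, and in an assay on membranes from liver for displacement of a labelled ligand from Sigma intracellular receptor 2 (Rattus norvegicus), read by scintillation counting, with a stated time of 120 min, in the presence of a further agent that is not named here (a higher number here means a weaker inhibitor, a lower number a stronger inhibitor), compound 1 gives 93 nM. Compound 2 `O=c1oc(-c2ccccc2)nn1CCCCN1CCN(c2ccc(F)cc2)CC1` bears a 4-fluorophenyl instead, and in this assay compound 2 gives 686 nM. Going by the values given here, the single measured step is a 7.4-fold higher number from compound 1 to compound 2 (0.87 log units; beyond the scatter), so compound 2 stands with the higher number of the two, that is, as the weaker inhibitor of the pair.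

Compound 3 `O=c1oc(-c2ccccc2)nn1CCCCN1CCN(c2ccccn2)CC1` takes the next step from compound 2: pyridin-2-yl in place of 4-fluorophenyl on an amine nitrogen in a ring. Among the compounds with values here, no measured step compares one aromatic ring with another at this position; the only step recorded, from a cyclohexyl to an aromatic ring, was of modest size. Nothing therefore points to a large move in this assay in either direction, and the expectation is a number near that of compound 2, with wide uncertainty. The step expected from this change is a 1.3-fold higher number from compound 2 to compound 3 (0.12 log units; within the scatter). Compound 3 is therefore estimated at 900 nM, with a likely range from 250 nM to 3500 nM.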

Compound 3, inhibition constant: 2800 nM
Estimate against measurement, compound 3: 3.1-fold (0.49 log units) below; the range from low to high includes it.
By their numbers in this assay, from the lowest: compound 1; then compound 2; then compound 3.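

The swap between two aromatic rings is not neutral: this assay shows a 4.1-fold higher number from compound 2 to compound 3 (0.61 log units; beyond the scatter), so this position separates one aromatic ring from another and does not only separate cyclohexyl from an aromatic ring. Going by these compounds alone, measured against the cyclohexyl of compound 1, the pyridin-2-yl group gives a 30-fold higher number from compound 1 to compound 3 (1.48 log units; beyond the scatter), and the three groups now run in order from cyclohexyl through 4-fluorophenyl to pyridin-2-yl as the number rises, a wider spread than the single earlier step could show. This change also does two things at once, removing a fluorine and placing a nitrogen in the ring, which adds one hydrogen-bond acceptor, and no measurement here explains the loss or assigns it to either part of the change.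

A plain phenyl group would help to separate those two parts, showing whether the number tracks the loss of the fluorine or the arrival of the ring nitrogen, and a pyridin-4-yl group would show whether the place of that nitrogen in the ring matters. On these data alone, whether the lowest number belongs to cyclohexyl alone or extends to other non-aromatic groups, such as cyclopentyl or a simple butyl chain, also remains open.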